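A few compounds are considered here, and "the series" means these few. Any claim that something is new, unique, unknown or untested is made for them only; others in the source may bear on it.

Compound 2 `CN(C)C/C=C/C(=O)Nc1cccc(Nc2nc(N/N=C/c3ccncc3)ncc2Cl)c1` gives 25200 nM in an ADME assay on HT-29 cells (Homo sapiens) for inhibition, read by MTT assay, with a stated time of 72 h (a lower number here means a stronger inhibitor, a higher number a weaker inhibitor), the higher of the two numbers recorded so far. For the measured compounds named here, its only measured neighbour is compound 1 `CN(C)C/C=C/C(=O)Nc1cccc(Nc2nc(N/N=C/c3ccc(F)cc3F)ncc2Cl)c1`, which in this assay gives 2920 nM; the single step between them, an 8.6-fold higher number from compound 1 to compound 2 (0.94 log units; beyond the scatter), came from putting pyridin-4-yl in place of 2,4-difluorophenyl on the carbon with a double bond to nitrogen.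

Compound 3 `C/C(=N\Nc1ncc(Cl)c(Nc2cccc(NC(=O)/C=C/CN(C)C)c2)n1)c1ccc(F)cc1` has not yet been measured. Its change from compound 2 is a group of 10 heavy atoms (8 carbon, 1 nitrogen, 1 fluorine; one six-membered aromatic ring of carbon only) in place of a group of 8 heavy atoms (6 carbon, 2 nitrogen; one six-membered aromatic ring with 1 hetero atom), on a nitrogen on an aromatic ring: the six-membered aromatic ring with one hetero atom leaves and a six-membered ring of carbon only, carrying fluorine, enters, with a carbon added on the carbon that holds the double bond to nitrogen. Of the measured steps, only an 8.6-fold higher number from compound 1 to compound 2 (0.94 log units; beyond the scatter) bears on this, and it runs the opposite way to the change now made. A decrease in this assay is therefore expected for compound 3, of a size a 5.6-fold lower number from compound 2 to compound 3 (0.75 log units; beyond the scatter) somewhat smaller than that step, since the entering ring is not the same as that of compound 1. Compound 3 is estimated at 4500 nM, within 1500 nM to 13000 nM.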

Compound 3, half-maximal inhibitory concentration: 10200 nM
For compound 3 the middle estimate is 2.3-fold (0.36 log units) below the measured one, and the stated range covers the measured number.
By their numbers in this assay, from the lowest: compound 1; then compound 3; then compound 2.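

In this assay, a 2.5-fold lower number from compound 2 to compound 3 (0.39 log units; beyond the scatter), so a lower number than that of compound 2 is seen with a second group built on a six-membered ring of carbon only, and not with the 2,4-difluorophenyl group alone. At the same time, a 3.5-fold higher number from compound 1 to compound 3 (0.54 log units; beyond the scatter), which shows that groups with a carbon-only ring are not interchangeable on this nitrogen-linked side chain: compound 3 lies between the other two compounds, with both of its steps beyond the scatter. No measurement available here accounts for either step.

Each step into compound 3 changes the ring group and adds a carbon on the carbon that holds the double bond to nitrogen, and the step from compound 1 also changes the fluorine count, so the share of each change in the numbers stays unresolved. From the compounds shown here alone, it remains open how a plain phenyl ring carrying no fluorine, a methoxy group on the ring, or an ethyl group in place of the added carbon would compare with these three compounds.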